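Working notes: cytotoxicity after aryl exchange on the shared core

A few compounds are considered here, and "the series" means these few. Any claim that something is new, unique, unknown or untested is made for them only; others in the source may bear on it.

Three compounds of the shared core have been run in an ADME assay on MT4 cells (Homo sapiens) for cytotoxicity, read by MTT assay, with a stated time of 5 days; a higher number here means that more compound is tolerated, a lower number that less compound is tolerated. Compound 1 `Cc1ccc(-c2cnc(Nc3ccc(C#N)cc3)nc2Oc2c(C)cc(C#N)cc2C)cc1` gives 26100 nM. Compound 2 `Cc1cc(C#N)cc(C)c1Oc1nc(Nc2ccc(C#N)cc2)ncc1-c1ccoc1` gives 4980 nM, a step of a 5.2-fold lower number from compound 1 to compound 2 (0.72 log units; beyond the scatter). Compound 3 `Cc1cc(C#N)cc(C)c1Oc1nc(Nc2ccc(C#N)cc2)ncc1-c1cccc2ccccc12` is recorded only as a limit of the assay, > 267000 nM. Where compound 3 stands is therefore known only through the steps into it, an at least 10-fold higher number from compound 1 to compound 3 (1.00 log units; beyond the scatter) and an at least 53-fold higher number from compound 2 to compound 3 (1.72 log units; beyond the scatter), both upward and both beyond the scatter, and compound 3 is the most tolerated of the three as far as the numbers go.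

Compound 4 `Cc1cc(C#N)cc(C)c1Oc1nc(Nc2ccc(C#N)cc2)ncc1-c1ccc(C(F)(F)F)cc1` differs from compound 3 by 4-(trifluoromethyl)phenyl in place of naphthalen-1-yl on an aromatic carbon. The two steps that bear on this change are the two into compound 3, and both were large. Compound 4 carries, like compound 1, one six-membered aromatic ring of carbon only at that carbon, and compound 1 sits at 26100 nM, so a return toward that level is expected. The step of an at least 8.9-fold lower number from compound 3 to compound 4 (0.94 log units; beyond the scatter) is expected to be downward and beyond the scatter. Compound 4 is estimated at 30000 nM, within 8000 nM to 120000 nM.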

Compound 4, half-maximal cytotoxic concentration: 35000 nM
Compound 4: middle estimate off by 1.2-fold (0.07 log units), on the low side; measured number inside the range.
By their numbers in this assay, from the lowest: compound 2; then compounds 1 and 4 (each within the scatter of the next). At a limit, above all of these: compound 3.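

In this assay, 4-(trifluoromethyl)phenyl in place of 4-methylphenyl at this aromatic carbon gives a 1.3-fold higher number from compound 1 to compound 4 (0.13 log units; within the scatter), so this exchange at the far end of the ring leaves the number unresolved from that of compound 1. Against furan-3-yl the same group gives a 7.0-fold higher number from compound 2 to compound 4 (0.85 log units; beyond the scatter), so compound 2 now stands apart from both phenyl compounds shown, compound 1 and compound 4. Going from naphthalen-1-yl to 4-(trifluoromethyl)phenyl gives an at least 7.6-fold lower number from compound 3 to compound 4 (0.88 log units; beyond the scatter), a size that holds only as a bound, and compound 3 is recorded only as a limit: the limit of > 267000 nM in this assay, at which 1 of the 4 values shown sits.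

As far as these compounds go, whether an amine or a carboxylic acid on the phenyl ring would move the number at this carbon remains open. Also open is how a saturated group such as cyclohexyl would compare with the aromatic groups shown.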